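The source may report more compounds than this note shows. Statements on the series, on what has been measured and on what is new or still open speak of the compounds shown alone.

Working notes on the series. Compound 2 `Nc1ccccc1NC(=O)c1ccc(CSC(=S)N2CCN(c3cnccn3)CC2)cc1` in a functional assay on A-375 cells (Homo sapiens) for antiproliferative activity, read by CCK-8 assay, with a stated time of 72 h, tested at 2 uM (a lower number here means a weaker effect, a higher number a stronger effect of the compound at the concentration tested), gives 29.1%; compound 1 `Nc1ccccc1NC(=O)c1ccc(CSC(=S)N2CCN(c3ncccn3)CC2)cc1` in this assay gives 24%, and the two lie within the scatter of each other, so neither stands apart. Going by the values given here, the only measured step, a number 5.1 percentage points higher from compound 1 to compound 2 (within the scatter), also swaps the group on the ring amine nitrogen. Compound 3 `Nc1ccccc1NC(=O)c1ccc(CSC(=S)N2CCN(Cc3ccccc3)CC2)cc1` differs from compound 2 by benzyl in place of pyrazin-2-yl on an amine nitrogen in a ring. Among the compounds with values here, no measured step replaces an aromatic group there with benzyl, so no direction beyond the scatter is expected; compound 3 is estimated at 30% with a range of 10% to 55%, a step of a number 0.9 percentage points higher from compound 2 to compound 3 (within the scatter).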

Compound 3, a percentage reported as inhibition, at one concentration (the size of the read-out at that concentration, not a potency): 10.6%
Compound 3: the middle estimate sits 19.4 percentage points above what was measured, and the stated range covers the measured number.
By their numbers in this assay, from the lowest: compound 3; then compounds 1 and 2 (each within the scatter of the next).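

In this assay the group on the amine nitrogen in the ring does matter: there is a number 18.5 percentage points lower from compound 2 to compound 3 (beyond the scatter) and also a number 13.4 percentage points lower from compound 1 to compound 3 (beyond the scatter) for benzyl, whereas the swap between the two nitrogen-containing aromatic rings stayed within the scatter. Within these compounds, the two rings bonded directly to that nitrogen sit together, with benzyl apart from both. No measurement available here explains the change.

Benzyl differs from both rings in its extra carbon and in its ring of carbon only, so the two differences remain unseparated. Phenyl or pyridin-2-ylmethyl on the same nitrogen would tell them apart.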